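Aryl-alkynyl thiazole series: ring-nitrogen substitution and receptor modulation

This account rests on a few compounds, and the source may have more. Where it says the series, first, only, none or still open, it means among the compounds named here.

Measured compounds:
compound 1 `O=C1NCCc2nc(C#Cc3cccc(F)c3)sc21` gives 290 nM
compound 2 `CN1CCc2nc(C#Cc3cccc(F)c3)sc2C1` gives > 10000 nM
compound 3 `CCC(=O)N1CCc2nc(C#Cc3ccccc3)sc2C1` gives > 10000 nM

Three compounds of the series have been run in an assay on HEK293 cells for positive allosteric modulation of metabotropic glutamate receptor 5 (Homo sapiens), read by FLIPR, with a stated time of 1 h; on this read-out higher numbers stand for an effect only at larger amounts of compound and lower numbers for an effect already at smaller amounts. Among the measured compounds shown here, compound 1 is the only one with a number; for compound 1 the read-out is 290 nM. For compound 2 the read-out is a limit of the assay, > 10000 nM, not a number. For compound 3 the read-out is likewise a limit, > 10000 nM. Compound 3 therefore stands at the top edge of what this assay reports, together with compound 2 (the limit of > 10000 nM in this assay, at which 2 of the 3 values shown sit).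

The next compound, compound 4 `CC(C)S(=O)(=O)N1CCc2nc(C#Cc3ccccc3)sc2C1`, has not yet been measured in this assay. Compound 4 differs from compound 3 in a single place: isopropylsulfonyl in place of propanoyl on an amine nitrogen in a ring. For the measured compounds named here, no step between two measured compounds is available, so the expectation rests on where compound 3 sits alone.

With compound 3 already at the limit, compound 4 is expected to stay there as well: the expected step of a number no higher from compound 3 to compound 4 (the limit leaves the size open) is none beyond the scatter. For compound 4 the estimate in this assay is 10000 nM, with a range from 3000 nM to 30000 nM, and a limit rather than a number is the likely outcome.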

Compound 4, half-maximal effective concentration: > 10000 nM
Compound 4: only a limit was reported; the forecaster's own chance of this, stated with the estimate: 70%; the middle value lies on the limit itself.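

Compound 3 and compound 4 both give only a limit in this assay, so no step can be read between them: the limit of > 10000 nM in this assay, at which 3 of the 4 values shown sit. The compounds shown leave open whether any group on an amine nitrogen in a ring of this core gives a number rather than a limit, and how far apart compound 3 and compound 4 really lie.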